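Cyclopropane aryl replacement in a biphenyl amide series

The compounds below may be only part of what the source reports. "The series", "measured", "known", "first", "only" and "open" are said of these compounds alone.

Measured compounds in a functional assay for agonist activity at G protein-coupled receptor 88 (Homo sapiens), read by HTRF and cAMP accumulation; a lower number here means that less compound is needed, a higher number that more compound is needed for the effect:
compound 1, `CN[C@@H](CC(C)C)CN(C(=O)[C@@H]1C[C@H]1c1ccccc1)c1ccc(-c2ccccc2)cc1`: 2 nM
compound 2, `O=C([C@@H]1C[C@H]1c1ccccc1)N(CC1CCCNC1)c1ccc(-c2ccccc2)cc1`: 10 nM
compound 3, `CC[C@H](C)[C@H](N)CN(C(=O)[C@@H]1C[C@H]1c1ccc(OC)cc1)c1ccc(-c2ccccc2)cc1`: > 25000 nM

Compound 1 gives 2 nM in this assay and compound 2 gives 10 nM. Among the compounds with values here, the one measured step, a 5.0-fold higher number from compound 1 to compound 2 (0.70 log units; beyond the scatter), concerns the amine-bearing side chain and leaves the cyclopropane substituent untouched. Compound 3 is reported only as a limit, > 25000 nM, not as a number. It is the compound referred to by the limit of > 25000 nM in this assay, at which 1 of the 3 values shown sits.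

Compound 4, `CC[C@H](C)[C@H](N)CN(C(=O)[C@@H]1C[C@H]1C1CCCCC1)c1ccc(-c2ccccc2)cc1`, differs from compound 3 in one place: cyclohexyl in place of 4-methoxyphenyl on a saturated ring carbon. Within the data shown here, no measured step bears on this position; the step between compound 1 and compound 2 changes a different part of the molecule and gives no guide to the size or direction of a change at the cyclopropane. With compound 3 already at the limit, the outcome for compound 4 cannot be anchored to a number. Compound 4 is expected to remain at or near the limit, with an estimated value of 30000 nM in this assay and a range from 5000 nM to 100000 nM. The step that the limit leaves unreadable from compound 3 to compound 4 is accordingly expected to be none beyond the scatter, most probably again reported as a limit.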

Compound 4, half-maximal effective concentration: > 25000 nM
Compound 4: no number, only a limit; the forecaster's own chance of this, stated with the estimate: 75%; the middle value is on the limit's open side.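

Compound 3 and compound 4 are both reported only as limits in this assay, not as numbers, so no step between them can be read: the limit of > 25000 nM in this assay, at which 2 of the 4 values shown sit.

The compounds shown leave open which structural difference separates compound 3 and compound 4 from compound 1 and compound 2, since each differs from those two in more than one place.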